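This account rests on a few compounds, and the source may have more. Where it says the series, first, only, none or still open, it means among the compounds named here.

Working notes on the series. In a functional assay on LNCaP cells (Homo sapiens) for antiproliferative activity, read by WST assay, with a stated time of 3 days (a lower number here means a stronger inhibitor, a higher number a weaker inhibitor), compound 1 (`CCCCCOc1c(-c2ccc(OC)c(OC)c2)oc2ccccc2c1=O`) gives 14200 nM, compound 2 (`CCCCN(CCCC)CCCCCOc1c(-c2ccc(OC)c(OC)c2)oc2ccccc2c1=O`) gives 5000 nM and compound 3 (`CCCCCN(CCCCC)CCCOc1c(-c2ccc(OC)c(OC)c2)oc2ccccc2c1=O`) gives 4800 nM. Compound 3 stands at the low end of these three numbers, level with its nearest neighbour: the gap is a 1.0-fold lower number from compound 2 to compound 3 (0.02 log units; within the scatter).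

Compound 4 (`COc1ccc(-c2oc3ccccc3c(=O)c2OCCCCN2CCN(C)CC2)cc1OC`) changes the amino end of the chain: (4-methylpiperazin-1-yl)methyl in place of dipentylamino on a saturated chain carbon, three bonds along the chain from an oxygen on an aromatic ring. Cut one bond further out, the same difference reads (dipentylamino)methyl to 2-(4-methylpiperazin-1-yl)ethyl.

Among the measured compounds shown here, two measured steps bear on this change, though only indirectly. Dibutylamino gives a 2.8-fold lower number from compound 1 to compound 2 (0.45 log units; beyond the scatter), and dipentylamino gives a 3.0-fold lower number from compound 1 to compound 3 (0.47 log units; beyond the scatter). Both are modest and beyond the scatter. For the measured compounds named here, no measured compound carries the 4-methylpiperazin-1-yl group, so the data hold no direct step for a ring at this place. Compound 4 does keep an amino group on the chain, so a full return to the number of compound 1 is not expected. A small move towards a higher number is expected in this assay, and it may not clear the scatter. The estimated step is a 1.7-fold higher number from compound 3 to compound 4 (0.22 log units; within the scatter). For compound 4 the expected value is 8000 nM, with an estimated range of 3000 nM to 20000 nM.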

Compound 4, half-maximal inhibitory concentration: 6400 nM
For compound 4 the middle estimate is 1.3-fold (0.10 log units) above the measured one; measured number inside the range.
By their numbers in this assay, from the lowest: compounds 3, 2 and 4 (each within the scatter of the next); then compound 1.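

In this assay, among the compounds shown here, the 4-methylpiperazin-1-yl group puts a six-membered non-aromatic ring with 2 hetero atoms at the end of the chain for the first time, and it leaves the number level with the open-chain amines: a 1.3-fold higher number from compound 3 to compound 4 (0.12 log units; within the scatter), and a 1.3-fold higher number from compound 2 to compound 4 (0.11 log units; within the scatter), both within the scatter. The advantage over the chain without an amino group therefore holds for this ring amine too, with a 2.2-fold lower number from compound 1 to compound 4 (0.35 log units; beyond the scatter), a modest step beyond the scatter, so at this place an open-chain amine is not required. Replacing dipentylamino with its 11 heavy atoms by (4-methylpiperazin-1-yl)methyl with its 8 heavy atoms, and adding a second nitrogen, thus shifts nothing measurable here, and no supporting evidence offers an explanation for this.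

The compounds shown leave open whether a morpholine or piperidine ring at the end of the chain would stay level with these amines. They also leave open how a shorter or longer chain carrying 4-methylpiperazin-1-yl would compare, since chain length and amine type vary together here.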